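This account rests on a few compounds, and the source may have more. Where it says the series, first, only, none or still open, it means among the compounds named here.

Compound 2 `CCOC(=O)CCCCCOc1cccc(CN(C(=O)c2ccc(-c3cccc(C(C)=O)c3)cc2)C(C)C)c1` is the reference point for this comparison. In an ADME assay on Raji cells (Homo sapiens) for cytotoxicity, read by CellTiter-Glo and resazurin assay, with a stated time of 72 h (on this read-out lower numbers stand for an effect already at smaller amounts and higher numbers for an effect only at larger amounts of compound), compound 2 gives > 26000 nM, which is a limit of the assay rather than a number. Compound 1 `CC(=O)c1cccc(-c2ccc(C(=O)N(Cc3cccc(OCCCCCC(=O)O)c3)C(C)C)cc2)c1` differs from compound 2 in carrying hydrogen where compound 2 carries ethyl on an oxygen next to a carbonyl group. In this assay compound 1 gives > 26000 nM, also a limit. Compound 3 `CCOC(=O)CCCCCOc1cccc(CN(C(=O)c2ccc(-c3cccc(Oc4ccccc4)c3)cc2)C(C)C)c1` carries phenoxy in place of acetyl on an aromatic carbon relative to compound 2. In this assay compound 3 gives > 19600 nM, again a limit. The two measured steps are a step that the two limits leave unreadable from compound 1 to compound 2 and a step that the two limits leave unreadable from compound 2 to compound 3, and their size stays unreadable because the limit of > 26000 nM in this assay, at which 2 of the 3 values shown sit, and the limit of > 19600 nM in this assay, at which 1 of the 3 values shown sits, bound every value shown. Compound 4 `CCOC(=O)CCCCCOc1cccc(CN(C(=O)c2ccc(-c3ccc4c(c3)OCCO4)cc2)C(C)C)c1` is the compound not yet measured; it shows (2,3-dihydro-1,4-benzodioxin-6-yl in place of 3-acetylphenyl on an aromatic carbon), on an aromatic carbon of a six-membered aromatic ring of carbon only, para to a large group. Neither measured step offers a readable size for this change, and all three measured compounds sit at a limit, so no step beyond the scatter is expected in this assay in either direction. Compound 4 is therefore expected to give 40000 nM, between 20000 nM and 100000 nM. The step this estimate implies, a step that the limit leaves unreadable from compound 2 to compound 4, is expected to remain within the scatter.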

Compound 4, half-maximal effective concentration: > 24400 nM
Compound 4: a limit, no number (the forecaster's own chance of this, stated with the estimate: 85%); the middle value does not contradict the limit.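

In this assay compound 2 and compound 4 both sit at a limit rather than at a number, so no step can be read between them. The compounds shown leave open whether 3-acetylphenyl, phenoxy and 2,3-dihydro-1,4-benzodioxin-6-yl differ at all in this assay, and whether any change to the shared core would give a measurable value.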